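This account rests on a few compounds, and the source may have more. Where it says the series, first, only, none or still open, it means among the compounds named here.

Of the compounds shown here, three built on one shared core have been tested in a functional assay on MCF7 cells (Homo sapiens) for antiproliferative activity, read by sulforhodamine B assay, with a stated time of 48 h; on this read-out lower numbers stand for stronger inhibition and higher numbers for weaker inhibition. Compound 2, `COc1ccc(OS(=O)(=O)c2ccc(N3CCN(C)C3=O)cc2)cc1`, gives 95000 nM. Compound 1, `COc1ccc(OS(=O)(=O)c2ccc(N3CCN(C)C3=O)cc2)cc1OC`, gives 12000 nM. These two differ in a single place, (methoxy in place of hydrogen on an aromatic carbon), and that change produced a 7.9-fold lower number from compound 2 to compound 1 (0.90 log units; beyond the scatter). Compound 3, `CCN1CCN(c2ccc(S(=O)(=O)Oc3cc(OC)cc(OC)c3)cc2)C1=O`, gives 3500 nM, the lowest number among the three measured compounds. How the core of compound 3 differs from the core of compound 2 is not broken down here; only their two values can be compared, and compound 3 sits well below compound 2.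

Compound 4, `CCN1CCN(c2ccc(S(=O)(=O)Oc3cc(OC)c(OC)c(OC)c3)cc2)C1=O`, has not yet been measured. It differs from compound 3 by methoxy in place of hydrogen on an aromatic carbon. Among the measured compounds shown here, this is the same kind of change as the one from compound 2 to compound 1, but not the same: in compound 1 the entering group stands ortho to a methoxy group and meta to a large group, whereas in compound 4 it stands ortho to two methoxy groups and para to a large group. Because the earlier methoxy step was a 7.9-fold lower number from compound 2 to compound 1 (0.90 log units; beyond the scatter), a further lowering is expected, though a somewhat smaller one is estimated, a 2.9-fold lower number from compound 3 to compound 4 (0.46 log units; beyond the scatter), since the surroundings of the new group are not identical. Compound 4 is therefore expected to give about 1200 nM, estimated to lie between 300 nM and 5000 nM.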

Compound 4, half-maximal inhibitory concentration: 700 nM
Compound 4: the middle estimate sits 1.7-fold (0.23 log units) above what was measured, within the range that was stated.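

In this assay, putting a methoxy group in place of a hydrogen on an aromatic carbon lowers the number once more, giving a 5.0-fold lower number from compound 3 to compound 4 (0.70 log units; beyond the scatter). Set beside the earlier case, the two steps point the same way and cannot be told apart in size: the same change on two cores in this assay, a 7.9-fold lower number (0.90 log units; beyond the scatter) from compound 2 to compound 1 and a 5.0-fold lower number (0.70 log units; beyond the scatter) from compound 3 to compound 4, 1.6-fold (0.20 log units) apart, within the scatter of two such steps This shows that the gain from this change carried over between these two cores in this read-out, but it rests on only two pairs of compounds, so it is no general rule for the series, and it cannot say why the number falls or whether a third core would behave in the same way.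

The compounds shown leave open whether another group at the same place on the ring, ortho to two methoxy groups and para to a large group, such as an ethoxy group, a hydroxyl group or a fluorine atom, would lower the number as much as methoxy does. They also leave open whether a longer chain, such as propyl or butyl, in place of the ethyl group of compound 4 would change the number further, and whether the methoxy step would keep its size there.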